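The compounds below may be only part of what the source reports. "The series", "measured", "known", "first", "only" and "open" are said of these compounds alone.

Measured so far:
compound 1, `Cc1ccc(F)cc1NC[C@@H]1[C@@H](c2ccc(S(N)(=O)=O)cc2)C1(C)C`, in a functional assay on the whole organism with Mus musculus as the target, with stated times of 60 min and 30 min, at a dose of 1 mg/kg by the oral route (on this read-out lower numbers stand for less inhibition and higher numbers for more inhibition at the one dose given (going by the name of the read-out)), gives -9%;
compound 2, `CC1(C)[C@H](CNc2ccc(F)cc2C(F)(F)F)[C@H]1c1ccc(S(N)(=O)=O)cc1`, in this assay gives -18%.

Compound 2 stands close to compound 1 in this assay, the two numbers lying within the usual scatter of each other, and neither shows inhibition above the noise. Compound 3, `CC1(C)[C@@H](CNc2ccc(F)cc2C(F)(F)F)[C@@H]1c1ccc(S(N)(=O)=O)cc1`, has not yet been measured in this assay. It differs from compound 2 in this way: the two compounds have the same atoms and bonds and differ only in configuration as drawn: 2 of 2 stereo elements differ (all stereocentres are inverted: mirror images); a stereocentre at a saturated ring carbon is drawn R in compound 2 and S in compound 3; a stereocentre at a saturated ring carbon is drawn R in compound 2 and S in compound 3. Among the measured compounds shown here, no step between measured compounds that differ in one place is available, so there is no measured guide to what an inversion of both stereocentres does here. Given that compound 2 in this assay gives -18%, a number that itself lies inside the scatter around zero, compound 3 is expected to land near the same level, with the change from compound 2 to compound 3 estimated at a number 8 percentage points higher from compound 2 to compound 3 (within the scatter), no step beyond the scatter. Compound 3 is therefore estimated at -10% in this assay, within a range from -30% to 15%.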

Compound 3, a percentage reported as inhibition, in the whole organism at one dose (the size of the read-out at that dose, not a potency): 40%
Compound 3: the middle estimate sits 50 percentage points below what was measured; the measured number lies above the stated range.
By their numbers in this assay, from the lowest: compounds 2 and 1 (each within the scatter of the next); then compound 3.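

In this assay, inverting both stereocentres gives a number 58 percentage points higher from compound 2 to compound 3 (beyond the scatter), so with the atoms and bonds held fixed, the drawn configuration at the two saturated ring carbons decides the outcome at this single dose. Among the compounds shown here, the earlier numbers showed no inhibition above the noise, and compound 3 is the first to show that this structure can give a clear inhibition in the whole organism. The step can be assigned to configuration alone, with nothing entering or leaving: the fact that compounds 2 and 3 differ only in the configuration as drawn.

The compounds shown leave open whether one of the two stereocentres alone carries the step, since both change together in this pair. They also leave open whether the same configuration would give a similar number with a nitrile in place of the trifluoromethyl.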